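This account rests on a few compounds, and the source may have more. Where it says the series, first, only, none or still open, it means among the compounds named here.

Measured so far:
- Compound 1 `C=C1C(=O)[C@]23C[C@@]1(Cl)CC[C@H]2[C@@]12C=CC(=O)[C@](C)(C(=O)O1)[C@H]2[C@@H]3C(=O)OC`: 2900 nM
- Compound 2 `C=C1C(=O)[C@]23C[C@@]1(Cl)CC[C@H]2[C@@]12C=CC(=O)[C@](C)(C(=O)O1)[C@H]2[C@@H]3C(=O)OCc1ccccc1`: 4500 nM

Both numbers come from a functional assay on HT-29 cells (Homo sapiens) for cytotoxicity, read by MTT assay; on this read-out higher numbers stand for weaker inhibition and lower numbers for stronger inhibition. Compound 2 cannot be told apart from compound 1 on these data, since a 1.6-fold higher number from compound 1 to compound 2 (0.19 log units; within the scatter). Only these two compounds have been measured, so that comparison is all that can be said of its standing.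

The next compound is compound 3 `C=C1C(=O)[C@]23C[C@@]1(OCC)CC[C@H]2[C@@]12C=CC(=O)[C@](C)(C(=O)O1)[C@H]2[C@@H]3C(=O)OCc1ccccc1`, and it differs from compound 2 in one group: ethoxy in place of chloro on a saturated ring carbon. In words, this is ethoxy in place of chloro on a saturated ring carbon.

For the measured compounds named here, no measured step changes that carbon. Going by the values given here, the only step available, a 1.6-fold higher number from compound 1 to compound 2 (0.19 log units; within the scatter), is phenyl in place of hydrogen on a saturated chain carbon, so it bears on this change only indirectly. It shows one substitution on the shared core that did not move the number beyond the scatter. It gives no direction for the new change, so no step beyond the scatter is expected in this assay, although the uncertainty is wide.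

The expected change is a 1.1-fold higher number from compound 2 to compound 3 (0.05 log units; within the scatter). For compound 3 the estimated value is 5000 nM, with an expected range of 1600 nM to 15000 nM.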

Compound 3, half-maximal inhibitory concentration: 23300 nM
Estimate against measurement, compound 3: 4.7-fold (0.67 log units) below, and the stated range ends below it.
By their numbers in this assay, from the lowest: compounds 1 and 2 (each within the scatter of the next); then compound 3.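

In this assay, swapping chloro for ethoxy on this saturated ring carbon gives a 5.2-fold higher number from compound 2 to compound 3 (0.71 log units; beyond the scatter) and so points to weaker inhibition. The earlier change on the saturated chain carbon, a 1.6-fold higher number from compound 1 to compound 2 (0.19 log units; within the scatter) by comparison, did not separate its two compounds, so this ring carbon is the only one of the two changed places where the group present has made a readable difference. Nothing measured here shows which part of the swap matters, whether the larger count of heavy atoms, the added hydrogen-bond acceptor or the loss of the chlorine.

With only chloro and ethoxy shown on this carbon, it remains open whether a hydroxyl group, a methoxy group or an amine would stay close to compound 2, and whether a longer chain such as butoxy would raise the number further. As far as these compounds go, it is also open whether ethoxy in place of chloro would produce a step of similar size on the core of compound 1, which has hydrogen where compound 2 has phenyl.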